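The source may report more compounds than this note shows. Statements on the series, on what has been measured and on what is new or still open speak of the compounds shown alone.

Measured so far in a functional assay on A-375 cells (Homo sapiens) for inhibition, read by CCK-8 assay, with a stated time of 72 h, tested at 2 uM; a lower number here means less inhibition of growth, a higher number more inhibition of growth at the concentration tested:
Compound 1 `Nc1ccccc1NC(=O)/C=C/c1ccc(CSc2ccc(F)cc2)cc1` gives 28.8%.
Compound 2 `Nc1ccccc1NC(=O)/C=C/c1ccc(CSCCc2ccccc2)cc1` gives 41.9%.
Compound 3 `Nc1ccccc1NC(=O)c1ccc(CSCCc2ccccc2)cc1` gives 21.8%.

Compound 4 `Nc1ccccc1NC(=O)c1ccc(CSc2ccc(F)cc2)cc1` has not yet been measured in this assay. It stands to compound 3 as compound 1 stands to compound 2. The change from compound 3 to compound 4 is 4-fluorophenyl in place of phenethyl on a sulfur. The same change in the measured pair is 4-fluorophenyl in place of phenethyl on a sulfur, and there it made the step of a number 13.1 percentage points lower from compound 2 to compound 1 (beyond the scatter). Among the four compounds this change occurs twice in all. The difference between the core of compound 2 and the core of compound 3 is not broken down here; their values show compound 3 lower than compound 2, while compound 3 and compound 1 lie within the scatter of each other.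

Among the compounds with values here, for compound 4 the step of a number 11.8 percentage points lower from compound 3 to compound 4 (beyond the scatter) is expected to be of about the same modest size as a number 13.1 percentage points lower from compound 2 to compound 1 (beyond the scatter), since that single measured step is the only precedent for the change. As the starting value of compound 3 is already low, compound 4 is expected to give 10%, within a range from 0% to 24%.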

Compound 4, percent growth inhibition at one concentration: 19.4%
Beside the measured number, compound 4's estimate is 9.4 percentage points below it; measured number inside the range.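

In this assay, 4-fluorophenyl in place of phenethyl on the sulfur, on the core of compound 3, gives a number 2.4 percentage points lower from compound 3 to compound 4 (within the scatter). The two occurrences of this change can be set side by side: the same change on two cores in this assay, a number 13.1 percentage points lower (beyond the scatter) from compound 2 to compound 1 and a number 2.4 percentage points lower (within the scatter) from compound 3 to compound 4, 10.7 percentage points apart, within the scatter of two such steps. The change therefore carries from one core to the other without a measurable difference in its size, but two pairs do not show that its size is independent of the core, and only the first step lies beyond the scatter, so a consistent lowering across cores is not established.

The compounds shown carry only phenethyl and 4-fluorophenyl on the sulfur, so it remains open how an amine, a carboxylic acid or a longer chain in that place would behave on either core. Also open, as far as these compounds go, is whether the two steps would keep their relation at other concentrations, as each value here comes from a single tested concentration.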